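Nitrophenyl ether series: adding phenyl on the aryl ring

This account rests on a few compounds, and the source may have more. Where it says the series, first, only, none or still open, it means among the compounds named here.

Measured so far in an assay on membranes from Cerebral cortex for displacement of a labelled ligand from Neuronal acetylcholine receptor; alpha4/beta2 (Rattus norvegicus), with a stated time of 30 min; a lower number here means a stronger inhibitor, a higher number a weaker inhibitor:
compound 1 `CN1CCC[C@H]1COc1cccc([N+](=O)[O-])c1`, 31.2 nM
compound 2 `CN1CCC[C@H]1COc1cccc(C#CCCCCO)c1`, 4400 nM

Compound 1 gives the lowest number of the two, with compound 2 at a 140-fold higher number from compound 1 to compound 2 (2.15 log units; beyond the scatter), a change at a different place. Compound 3 `CN1CCC[C@H]1COc1cc(-c2ccccc2)cc([N+](=O)[O-])c1` differs from compound 1 by phenyl in place of hydrogen on an aromatic carbon. For the measured compounds named here, no measured step covers this change; the only step in hand shows the series is sensitive to larger substituents on the aryl ring. A moderate rise in this assay is expected: a 4.8-fold higher number from compound 1 to compound 3 (0.68 log units; beyond the scatter), estimated for compound 3 at 150 nM, range 30 nM to 800 nM.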

Compound 3, inhibition constant: 330 nM
Beside the measured number, compound 3's estimate is 2.2-fold (0.34 log units) below it; the range from low to high includes it.
By their numbers in this assay, from the lowest: compound 1; then compound 3; then compound 2.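

In this assay, phenyl in place of hydrogen on an aromatic carbon, meta to a nitro group, gives an 11-fold higher number from compound 1 to compound 3 (1.02 log units; beyond the scatter) with the nitro group kept. For the compounds shown here, the earlier pair changed only the group at the nitro position, so this is the first sign that a second site on the ring also affects the number. A single large aryl substituent is enough to produce a step beyond the scatter.

On these data alone, whether methyl, an amine or a carboxylic acid at this place would give a smaller step remains open. No data at hand bear on the reason for this step.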